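Aminopyridine for Methylimidazole: Solubility Outlook for Compound 4

The source may report more compounds than this note shows. Statements on the series, on what has been measured and on what is new or still open speak of the compounds shown alone.

Measured compounds:
compound 1 `Cc1cc(Cl)c(-c2ncc[nH]2)cc1NC(=O)c1ccc(OCc2ccccn2)cc1`, < 1000 nM
compound 2 `Cc1cc(C)c(-c2cn(C)cn2)cc1NC(=O)c1ccc(OCc2ccccn2)cc1`, 8000 nM
compound 3 `Cc1ccc(-c2ncc[nH]2)c(C)c1NC(=O)c1ccc(OCc2ccccn2)cc1`, 69000 nM

In a physicochemical assay for solubility, at pH 7.4 (on this read-out higher numbers stand for higher solubility and lower numbers for lower solubility), compound 1 reaches only a limit, < 1000 nM, and the limit of < 1000 nM in this assay, at which 1 of the 3 values shown sits, records this. Of the two numbers obtained, compound 2 stands lowest with 8000 nM; the nearest number is that of compound 3, 69000 nM, which lies beyond the scatter. Compound 4 `Cc1cc(C)c(-c2cccc(N)n2)cc1NC(=O)c1ccc(OCc2ccccn2)cc1` has not been measured in this assay. It differs from compound 2 by 6-aminopyridin-2-yl in place of 1-methyl-1H-imidazol-4-yl on an aromatic carbon. Within the data shown here, no measured pair in this set shares that change, so the direction of the step is open; a step no larger than the scatter is expected, a 1.3-fold higher number from compound 2 to compound 4 (0.10 log units; within the scatter). Compound 4 is accordingly estimated at 10000 nM, within a range of 2000 nM to 50000 nM.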

Compound 4, solubility: 2000 nM
The estimate for compound 4 lay 5.0-fold (0.70 log units) above the measured number; measured number inside the range.
By their numbers in this assay, from the lowest: compound 4; then compound 2; then compound 3. At a limit, below all of these: compound 1.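

In this assay, among these compounds, 6-aminopyridin-2-yl in place of 1-methyl-1H-imidazol-4-yl gives the first step that can be read at this position, on an aromatic carbon ortho to a methyl group and para to a methyl group: a 4.0-fold lower number from compound 2 to compound 4 (0.60 log units; beyond the scatter). The number at this position therefore moves with the group placed there, and this exchange moves it downward. Nothing measured here accounts for the step.

The compounds shown leave open whether the step follows the amine or the six-membered ring. A plain pyridin-2-yl group at this position would separate the two.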